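The compounds below may be only part of what the source reports. "The series", "measured", "known", "first", "only" and "open" are said of these compounds alone.

In an ADME assay on MRC5 cells (Homo sapiens), read by MTT assay, with a stated time of 72 h (a higher number here means a weaker inhibitor, a lower number a stronger inhibitor), compound 3 `CN(C)c1ncnc2c1c(-c1ccsc1)cn2[C@@H]1O[C@H](CO)[C@@H](O)[C@H]1O` gives > 100000 nM, which is a limit of the assay and not a number. With furan-3-yl in place of thiophen-3-yl, compound 2 `CN(C)c1ncnc2c1c(-c1ccoc1)cn2[C@@H]1O[C@H](CO)[C@@H](O)[C@H]1O` gives > 100000 nM, likewise a limit. Compound 3 therefore stands at the limit of > 100000 nM in this assay, at which 2 of the 3 values shown sit. Among the compounds with values here, the one measured step here is a step that the two limits leave unreadable from compound 2 to compound 3, so it offers no size to carry forward.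

Compound 4 `CN(C)c1ncnc2c1c(-c1cc3ccccc3o1)cn2[C@@H]1O[C@H](CO)[C@@H](O)[C@H]1O` changes the group on an aromatic carbon of the shared core, with 1-benzofuran-2-yl in place of thiophen-3-yl on an aromatic carbon. The nearest guide is compound 1 `CNc1ncnc2c1c(-c1cc3ccccc3o1)cn2[C@@H]1O[C@H](CO)[C@@H](O)[C@H]1O`, which bears the same 1-benzofuran-2-yl group on a core differing elsewhere and gives a measured 75300 nM. On the strength of that value for compound 1 at 75300 nM, a small move towards stronger inhibition in this assay is expected. Even so, a result at the limit of the assay remains quite possible for compound 4. The expected change is an at least 1.5-fold lower number from compound 3 to compound 4 (0.18 log units; that floor lies within the scatter). The estimate for compound 4 is 65000 nM, with an expected range from 20000 nM to 100000 nM.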

Compound 4, half-maximal inhibitory concentration: > 100000 nM
Compound 4 was reported as a limit; the forecaster's own chance of this, stated with the estimate: 45%; middle value at least 1.5-fold (0.18 log units) away from the limit.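

In this assay, compound 4 with its 1-benzofuran-2-yl group gives > 100000 nM, which is a limit of the assay and not a number. Within the data shown here, the steps to compound 4 from compound 2 and from compound 3 cannot be read, as both ends of each are limits, and the one readable step, for methyl in place of hydrogen on a nitrogen on an aromatic ring, is an at least 1.3-fold higher number from compound 1 to compound 4 (0.12 log units; that floor lies within the scatter). This change of group on the aromatic carbon therefore brings no number into the series, and only compound 1 stands apart from the others: the limit of > 100000 nM in this assay, at which 3 of the 4 values shown sit.

The compounds shown leave open whether thiophen-3-yl or furan-3-yl would give a number on the core of compound 1. They also leave open what an amine or a carboxylic acid on that aromatic carbon would give.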